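The compounds below may be only part of what the source reports. "The series", "measured", "known", "first", "only" and "open" are said of these compounds alone.

Of the compounds shown here, three carrying a trifluoromethylphenyl group have been measured in a functional assay on the whole organism (strain ICR) for inhibition, with Mus musculus as the target, with stated times of 7 days and 1 h, at a dose of 10 umol/kg by the intraperitoneal route; a lower number here means less inhibition, a higher number more inhibition at the dose given (going by the name of the read-out). Compound 1 `O=C(O)c1cc(O)c2ccc(-c3ccc(C(F)(F)F)cc3)cc2c1` gives 64.2%. Compound 2 `C#CCCCCN1CCC(c2ccc(-c3cc(C(=O)O)cc4cc(-c5ccc(C(F)(F)F)cc5)ccc34)cc2)CC1` gives 75.9%. Compound 3 `NCCCNC(=O)c1ccc(-c2cc(C(=O)O)cc(-n3cc(-c4ccc(C(F)(F)F)cc4)nn3)c2)s1` gives 91.5%, the highest of the three numbers: the nearest, compound 2, lies lower by a margin beyond the usual scatter, and compound 1 lies lower still, also beyond the scatter.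

The next compound, compound 4 `O=C(O)c1cc(-c2ccc(C3CCNCC3)cc2)cc(-n2cc(-c3ccc(C(F)(F)F)cc3)nn2)c1`, is to be measured in this assay. It differs from compound 3 in one place: 4-(piperidin-4-yl)phenyl in place of 5-((3-aminopropyl)carbamoyl)thiophen-2-yl on an aromatic carbon. No step between measured compounds covers this change, so the expectation rests on the numbers shown. Compound 4 shares its piperidinyl-phenyl group with compound 2, which gives 75.9% in this assay, while compound 3 gives the highest number of the set. The author therefore expects a downward step of moderate size a number 17.5 percentage points lower from compound 3 to compound 4 (beyond the scatter), one that would still leave compound 4 clearly inhibiting. The estimated inhibition for compound 4 in this assay is 74%, with a range from 55% to 90%.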

Compound 4, a percentage reported as inhibition, in the whole organism at one dose (the size of the read-out at that dose, not a potency): 67.4%
Estimate against measurement, compound 4: 6.6 percentage points above, within the range that was stated.
By their numbers in this assay, from the lowest: compounds 1, 4 and 2 (each within the scatter of the next, the first and the last beyond it); then compound 3.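

In this assay, placing 4-(piperidin-4-yl)phenyl instead of 5-((3-aminopropyl)carbamoyl)thiophen-2-yl on this aromatic carbon, meta to a carboxy group, goes with a number 24.1 percentage points lower from compound 3 to compound 4 (beyond the scatter). Going by these compounds alone, this is the first comparison in the set that isolates one place, and it shows that the read-out responds to the group held at this position, while compound 4 still gives 67.4%. The change replaces the thiophene, the carbamoyl link and the amine all at once, and no measurement bears on why the number falls.

The compounds shown leave open which of these parts carries the difference. A phenyl ring bearing the 3-aminopropyl carbamoyl chain, or a thiophene bearing a piperidine, would begin to separate the ring from the amine.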